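Methyl in place of phenyl on a carbonyl carbon

This account rests on a few compounds, and the source may have more. Where it says the series, first, only, none or still open, it means among the compounds named here.

For the measured compounds named here, in an ADME assay on HepG2 2.2.15 cells (Homo sapiens) for cytotoxicity, read by MTT assay (a higher number here means that more compound is tolerated, a lower number that less compound is tolerated), compound 3 `C=C1CC[C@@H]2[C@](C)(COC(=O)c3ccccc3)[C@H](O)CC[C@@]2(C)[C@@H]1C/C=C1\C=COC1=O` gives 82000 nM, the lowest number measured so far. Compound 1 `C=C1CC[C@@H]2[C@](C)(COC(=O)/C=C/c3ccccc3)[C@H](O)CC[C@@]2(C)[C@@H]1C/C=C1\C=COC1=O` gives 271000 nM. Compound 2 `C=C1CC[C@@H]2[C@](C)(COC(=O)c3ccco3)[C@H](O)CC[C@@]2(C)[C@@H]1C/C=C1\C=COC1=O` is reported only as a limit of the assay, > 2150000 nM. Compound 4 `C=C1CC[C@@H]2[C@](C)(COC(C)=O)[C@H](O)CC[C@@]2(C)[C@@H]1C/C=C1\C=COC1=O` carries methyl in place of phenyl on a carbonyl carbon. Three measured steps change the group at this same place: a 3.3-fold lower number from compound 1 to compound 3 (0.52 log units; beyond the scatter), an at least 7.9-fold higher number from compound 1 to compound 2 (0.89 log units; beyond the scatter) and an at least 26-fold lower number from compound 2 to compound 3 (1.41 log units; beyond the scatter). Both groups other than phenyl sit higher in this assay, although neither is methyl, so a modest rise is expected. The expected step is a 4.3-fold higher number from compound 3 to compound 4 (0.63 log units; beyond the scatter). Compound 4 is estimated at 350000 nM, with an expected range from 90000 nM to 1800000 nM.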

Compound 4, half-maximal cytotoxic concentration: 334000 nM
The estimate for compound 4 lay 1.0-fold (0.02 log units) above the measured number; low and high end bracket the measured number.
By their numbers in this assay, from the lowest: compound 3; then compounds 1 and 4 (each within the scatter of the next). At a limit, above all of these: compound 2.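

In this assay, replacing phenyl with methyl gives a 4.1-fold higher number from compound 3 to compound 4 (0.61 log units; beyond the scatter), so an aromatic ring on this carbonyl carbon is not needed for a higher number, while replacing 2-phenylethenyl with methyl gives a 1.2-fold higher number from compound 1 to compound 4 (0.09 log units; within the scatter), which leaves those two groups unseparated. Replacing furan-2-yl with methyl gives an at least 6.4-fold lower number from compound 2 to compound 4 (0.80 log units; beyond the scatter), which sets furan-2-yl apart from methyl as well as from phenyl. Compound 2 is only a limit of the assay: the limit of > 2150000 nM in this assay, at which 1 of the 4 values shown sits.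

As far as these compounds go, it remains open whether a longer chain, an amine or a thiophene ring at this place would stay near methyl or reach the range of furan-2-yl.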